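From a 4-chlorobenzyl to a 5-bromo-2-chlorobenzyl group

A few compounds are considered here, and "the series" means these few. Any claim that something is new, unique, unknown or untested is made for them only; others in the source may bear on it.

In a functional assay on NCI-H460 cells (Homo sapiens) for inhibition, read by sulforhodamine B assay, with a stated time of 48 h (on this read-out higher numbers stand for weaker inhibition of growth and lower numbers for stronger inhibition of growth), compound 1 `Fc1ccc(Cn2cc(CCCOc3cccc4cccnc34)nn2)cc1` gives 34.4 ug/mL, compound 2 `Clc1ccc(Cn2cc(CCCOc3cccc4cccnc34)nn2)cc1` gives 11.2 ug/mL and compound 3 `FC(F)(F)Oc1ccc(Cn2cc(CCCOc3cccc4cccnc34)nn2)cc1` gives 10.4 ug/mL. Compound 2 therefore stands with compound 3 at the low end of these numbers. The measurements show a 1.1-fold lower number from compound 2 to compound 3 (0.03 log units; within the scatter), a gap too small to separate them. Chloro in place of fluoro gives a 3.1-fold lower number from compound 1 to compound 2 (0.49 log units; beyond the scatter), and trifluoromethoxy in place of fluoro gives a 3.3-fold lower number from compound 1 to compound 3 (0.52 log units; beyond the scatter). Compound 4 `Clc1ccc(Br)cc1Cn1cc(CCCOc2cccc3cccnc23)nn1` is still unmeasured, and its change is 5-bromo-2-chlorophenyl in place of 4-chlorophenyl on a saturated chain carbon bound to an aromatic nitrogen: 5-bromo-2-chlorophenyl replaces 4-chlorophenyl. Going by the values given here, no measured compound carries bromine, so these modest steps offer only loose guidance, and no clear shift is expected. The expected change is a 1.2-fold lower number from compound 2 to compound 4 (0.07 log units; within the scatter). For compound 4 the estimated value is 9.5 ug/mL, with an expected range of 4 ug/mL to 23 ug/mL.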

Compound 4, concentration for 50% growth inhibition: 7.9 ug/mL
The estimate for compound 4 lay 1.2-fold (0.08 log units) above the measured number; the measured number falls inside the stated range.
By their numbers in this assay, from the lowest: compounds 4, 3 and 2 (each within the scatter of the next); then compound 1.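

In this assay, 5-bromo-2-chlorophenyl in place of 4-chlorophenyl gives a 1.4-fold lower number from compound 2 to compound 4 (0.15 log units; within the scatter), so this position, on a saturated chain carbon bound to an aromatic nitrogen, takes an added bromine and a shifted chlorine with no change that stands clear of the scatter. The other step, 5-bromo-2-chlorophenyl in place of 4-fluorophenyl, gives a 4.4-fold lower number from compound 1 to compound 4 (0.64 log units; beyond the scatter), and so places the new group with the chloro and trifluoromethoxy compounds, clear of the fluoro one. Nothing available explains these numbers.

The compounds shown do not separate the part played by the bromine from that of the moved chlorine. On these data alone, how a ring carrying an amine or a carboxylic acid would behave here also remains open.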